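The source may report more compounds than this note shows. Statements on the series, on what has been measured and on what is new or still open speak of the compounds shown alone.

Values in a functional assay on HCT-8 cells (Homo sapiens) for antiproliferative activity, read by MTT assay, with a stated time of 48 h (a lower number here means a stronger inhibitor, a higher number a weaker inhibitor), for the measured compounds:
compound 1 `COc1ccc2c(/C=C(\C)C(=O)c3cc(OC)c(OC)c([Se]C)c3)cn(C)c2c1` gives 25 nM
compound 2 `COc1ccc2c(/C=C/C(=O)c3cc(OC)c(OC)c(SC)c3)cn(C)c2c1` gives 157 nM
compound 3 `COc1ccc2c(/C=C(\C)C(=O)c3cc(OC)c(OC)c([Se]C)c3)c[nH]c2c1` gives 29 nM

Compound 1 stands at the low end of these numbers together with compound 3, the two lying within the scatter of each other, and its number is well under that of compound 2. Compound 4 `COc1cc(C(=O)/C(C)=C/c2cn(C)c3ccccc23)cc([Se]C)c1OC` keeps the core of compound 1 with a single change: hydrogen in place of methoxy on an aromatic carbon, in words hydrogen in place of methoxy on an aromatic carbon. Within the data shown here, the only measured single-place step is a 1.2-fold higher number from compound 1 to compound 3 (0.06 log units; within the scatter), which swaps hydrogen in place of methyl on an aromatic nitrogen. Among the measured compounds shown here, that is a different place and a different group, so it bears only weakly on this change, and no measured pair tests the loss of this methoxy. With so little direct evidence, a modest rise in the number is expected, and the range has to stay wide. The expected size is a 2.4-fold higher number from compound 1 to compound 4 (0.38 log units; beyond the scatter), which is an estimate and no more. Compound 4 is therefore estimated at 60 nM, with an expected range from 15 nM to 300 nM.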

Compound 4, half-maximal inhibitory concentration: 48 nM
The estimate for compound 4 lay 1.3-fold (0.10 log units) above the measured number; measured number inside the range.
By their numbers in this assay, from the lowest: compounds 1, 3 and 4 (each within the scatter of the next); then compound 2.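

Compounds 1, 2 and 3 all carry this methoxy, so they could say nothing about what it contributes. Putting hydrogen in its place on the aromatic carbon gives, in this assay, a 1.9-fold higher number from compound 1 to compound 4 (0.28 log units; within the scatter), so with the rest of the structure unchanged, this methoxy can be lost without a difference that stands clear of ordinary repeat variation. No measurement shown here offers a reason for this result.

The compounds shown compare only methoxy and hydrogen on this carbon, so the outcome with a fluorine atom, an amine or a longer chain such as butoxy remains open. Also open, going by these compounds, is whether hydrogen is equally well accepted here when the aromatic nitrogen carries hydrogen rather than methyl, as it does in compound 3.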